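The source may hold more compounds than are shown below. What is called first, only, known or untested is meant among the compounds shown, and "the series" means these compounds.

In an ADME assay on Vero cells (Chlorocebus sabaeus) for cytotoxicity, read by fluorescence and resazurin assay, with a stated time of 3 days (a higher number here means that more compound is tolerated, a lower number that less compound is tolerated), compound 1, `CC(=O)C[C@H]1O[C@@H](On2cc(CN3C(=O)C(=O)c4ccccc43)nn2)[C@H](OC(C)=O)[C@@H](OC(C)=O)[C@@H]1OC(C)=O`, gives 137000 nM. Compound 2, `CC(=O)C[C@H]1O[C@@H](On2cc(CN3C(=O)/C(=N\Nc4ccc(Br)cc4)c4ccccc43)nn2)[C@H](OC(C)=O)[C@@H](OC(C)=O)[C@@H]1OC(C)=O`, gives 116000 nM, and compound 3, `CC(=O)C[C@H]1O[C@@H](On2cc(CN3C(=O)/C(=N\Nc4ccc(Br)cc4)c4ccccc43)nn2)[C@H](OC(C)=O)[C@@H](OC(C)=O)[C@H]1OC(C)=O`, gives 83400 nM. The three numbers sit within the usual scatter of one another, so none of them can be set apart from the rest. For the measured compounds named here, the only step between two compounds that differ in a single place is a 1.4-fold lower number from compound 2 to compound 3 (0.14 log units; within the scatter), and it goes with the fact that compounds 2 and 3 differ only in the configuration as drawn; it carries no information about swapping one halogen-bearing ring for another.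

Compound 4, `CC(=O)C[C@H]1O[C@@H](On2cc(CN3C(=O)/C(=N\Nc4cccc(Cl)c4)c4ccccc43)nn2)[C@H](OC(C)=O)[C@@H](OC(C)=O)[C@H]1OC(C)=O`, differs from compound 3 in that (3-chlorophenyl in place of 4-bromophenyl on an amine nitrogen). Going by the values given here, no measured step speaks to this change, so the expectation rests on the spread of the three numbers alone, which show no movement beyond the scatter across all the changes made so far. For compound 4 the expected step is a 1.0-fold lower number from compound 3 to compound 4 (0.02 log units; within the scatter), that is, no change beyond the scatter. Compound 4 is therefore estimated at 80000 nM in this assay, with a likely range from 40000 nM to 160000 nM.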

Compound 4, half-maximal cytotoxic concentration: 87900 nM
Beside the measured number, compound 4's estimate is 1.1-fold (0.04 log units) below it; the range from low to high includes it.
By their numbers in this assay, from the lowest: compounds 3, 4, 2 and 1 (each within the scatter of the next).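

In this assay, replacing 4-bromophenyl with 3-chlorophenyl on the amine nitrogen gives a 1.1-fold higher number from compound 3 to compound 4 (0.02 log units; within the scatter) and so leaves the number within the scatter. Among the compounds shown, this is the only step that changes this aryl group, and it shows that this particular swap, with both the halogen and its printed ring position differing, produces no change that can be told from measurement noise. Nothing in the available evidence bears on why this result comes out as it does.

The halogen and its ring position differ together in this one step, so the contribution of each cannot be read separately. Also open, on these data alone, is whether a phenyl ring carrying an amine or a carboxylic acid, or a longer alkyl chain in place of the ring, would stay within the scatter in this assay as well.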